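From 2-chlorophenyl to thiophen-2-yl on a shared core

This account rests on a few compounds, and the source may have more. Where it says the series, first, only, none or still open, it means among the compounds named here.

- compound 1 `C=CC(=O)N1C(=O)CC(c2ccc(C)cc2)Sc2ccccc21`: 94400 nM
- compound 2 `C=CC(=O)N1C(=O)CC(c2ccc(Br)cc2)Sc2ccccc21`: 126000 nM
- compound 3 `C=CC(=O)N1C(=O)CC(c2ccccc2Cl)Sc2ccccc21`: 91400 nM

All three were tested in a functional assay on HL-60 cells (Homo sapiens) for cytotoxicity, read by CCK-8 assay, with a stated time of 24 h (a lower number here means a stronger inhibitor, a higher number a weaker inhibitor), and compound 3 stands level with the other two. The steps reaching it, a 1.0-fold lower number from compound 1 to compound 3 (0.01 log units; within the scatter) and a 1.4-fold lower number from compound 2 to compound 3 (0.14 log units; within the scatter), are small. Compound 4 `C=CC(=O)N1C(=O)CC(c2cccs2)Sc2ccccc21` keeps the shared core but carries thiophen-2-yl in place of 2-chlorophenyl on a saturated ring carbon. The two steps above swap the group at that same carbon, and a 1.3-fold higher number from compound 1 to compound 2 (0.13 log units; within the scatter), a change on that group, is also small. Among the measured compounds shown here, no thiophen-2-yl compound has been measured here, so this evidence is indirect. The expected step in this assay is a 1.1-fold higher number from compound 3 to compound 4 (0.04 log units; within the scatter), with nothing expected beyond the scatter. For compound 4 the estimated value is 100000 nM, with an expected range from 55000 nM to 180000 nM.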

Compound 4, half-maximal inhibitory concentration: 695000 nM
For compound 4 the middle estimate is 7.0-fold (0.84 log units) below the measured one; the measured number lies above the stated range.
By their numbers in this assay, from the lowest: compounds 3, 1 and 2 (each within the scatter of the next); then compound 4.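

The substituted phenyl groups stayed level with one another, but the saturated ring carbon next to the ring sulfur does respond to its group: in this assay, thiophen-2-yl gives a 7.6-fold higher number from compound 3 to compound 4 (0.88 log units; beyond the scatter) and a 7.4-fold higher number from compound 1 to compound 4 (0.87 log units; beyond the scatter) and a 5.5-fold higher number from compound 2 to compound 4 (0.74 log units; beyond the scatter) as its steps. Changes among these six-membered carbon rings did not reveal this sensitivity, which appears only with a five-membered aromatic ring holding one hetero atom. Nothing measured here explains this weaker result.

The compounds shown cannot separate ring size from the ring sulfur. Unsubstituted phenyl, furan-2-yl or a phenyl ring carrying an amine could show which of the two matters.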